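A few compounds are considered here, and "the series" means these few. Any claim that something is new, unique, unknown or untested is made for them only; others in the source may bear on it.

Measured compounds:
compound 1 `OCc1nnc(-c2ccc(N3CCC(Oc4ccccc4C(F)(F)F)CC3)nn2)s1` gives 3.2 nM
compound 2 `CC(C)(C)c1nnc(-c2ccc(N3CCC(Oc4ccccc4C(F)(F)F)CC3)nn2)s1` gives 710 nM

For the measured compounds named here, compound 2 stands with the highest of the two numbers in an assay on microsomes from liver for inhibition of acyl-CoA desaturase 1 (Rattus norvegicus); on this read-out higher numbers stand for weaker inhibition and lower numbers for stronger inhibition; the nearest is compound 1, and the single measured step, a 220-fold higher number from compound 1 to compound 2 (2.35 log units; beyond the scatter), is the only one that bears on the change considered here. Compound 3 `Oc1nnc(-c2ccc(N3CCC(Oc4ccccc4C(F)(F)F)CC3)nn2)s1` differs from compound 2 by hydroxy in place of tert-butyl on an aromatic carbon. The step that leaves tert-butyl for hydroxymethyl is reversed in spirit here: the tert-butyl that went with the high number of compound 2 is taken out again, and a small oxygen-bearing group comes in, as in compound 1. Because a 220-fold higher number from compound 1 to compound 2 (2.35 log units; beyond the scatter) was large, a large step back down is expected, an 89-fold lower number from compound 2 to compound 3 (1.95 log units; beyond the scatter), with the width of the range reflecting that hydroxy and hydroxymethyl are not the same group. Compound 3 is therefore estimated at 8 nM, between 2 nM and 40 nM.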

Compound 3, half-maximal inhibitory concentration: 6.1 nM
For compound 3 the middle estimate is 1.3-fold (0.12 log units) above the measured one, within the range that was stated.
By their numbers in this assay, from the lowest: compounds 1 and 3 (each within the scatter of the next); then compound 2.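

Replacing tert-butyl with hydroxy restores a low number in this assay (a 120-fold lower number from compound 2 to compound 3 (2.07 log units; beyond the scatter)), so the low number seen with hydroxymethyl is not unique to that group. On this carbon of the ring, hydroxy and hydroxymethyl cannot be told apart (a 1.9-fold higher number from compound 1 to compound 3 (0.28 log units; within the scatter)), and both groups carry a hydrogen-bond donor, which tert-butyl lacks. Nothing at hand explains these differences.

The three compounds cannot show whether the low numbers go with the hydrogen-bond donor or simply with the smaller size of the group, since tert-butyl differs from the other two in both respects. A methyl or methoxy group would help separate these readings, while an amine or a carboxylic acid would show how far other groups bearing a hydrogen-bond donor are accepted here.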